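Compound 3: a different aryl group on the aromatic oxygen

The compounds below may be only part of what the source reports. "The series", "measured", "known", "first", "only" and "open" are said of these compounds alone.

Among the compounds with values here, compound 1 `CC(C)NC(=O)c1cccnc1Oc1ccc(F)cc1` gives 0.001 mg/kg in a functional assay on the whole organism with Mus musculus as the target (a higher number here means that more compound is needed for the effect, a lower number that less compound is needed), whereas compound 2 `O=C(NCc1ccccc1)c1cccnc1Oc1ccc(F)cc1` gives 0.01 mg/kg, the higher of the two numbers; the only step recorded is a 10-fold higher number from compound 1 to compound 2 (1.00 log units; beyond the scatter). Compound 3 `COc1cccc(Oc2ncccc2C(=O)NCc2ccccc2)c1` differs from compound 2 in one place: 3-methoxyphenyl in place of 4-fluorophenyl on an oxygen on an aromatic ring. Within the data shown here, the recorded step concerns the amide-type nitrogen, not the oxygen on the aromatic ring, so no measured step bears on this change, and the expectation is a step of no more than the scatter, with wide uncertainty. Compound 3 is therefore expected to give 0.01 mg/kg, between 0.002 mg/kg and 0.05 mg/kg, an expected step of no change at the digits printed from compound 2 to compound 3 (within the scatter).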

Compound 3, minimum effective dose: 0.01 mg/kg
Compound 3: the middle estimate sits on the measured number at the digits printed; the measured number falls inside the stated range.
By their numbers in this assay, from the lowest: compound 1; then compounds 2 and 3 (each within the scatter of the next).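

In this assay, within the data shown here, 3-methoxyphenyl in place of 4-fluorophenyl on an oxygen on an aromatic ring gives no change at the digits printed from compound 2 to compound 3 (within the scatter) with the benzyl group kept on the amide nitrogen, the first reading at this position. The entering group counts a hydrogen-bond acceptor that the leaving group lacks, yet the numbers of these two compounds stay within the scatter. No measured evidence here offers an explanation for this result. Still open, going by these compounds, is whether this exchange would hold with the isopropyl group of compound 1 on the amide nitrogen, and how an amine or a carboxylic acid on this aryl ring would read.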